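The source may hold more compounds than are shown below. What is called first, only, known or untested is meant among the compounds shown, and "the series" means these compounds.

Values in a functional assay on HCT-116 cells (Homo sapiens) for antiproliferative activity, read by MTT assay, with a stated time of 72 h; a higher number here means a weaker inhibitor, a lower number a stronger inhibitor:
compound 1 `C=CC(=O)Nc1nc(-c2ccccc2)cs1` gives 18600 nM
compound 2 `C=CC(=O)N(CC(=O)OC(C)(C)C)c1nc(-c2ccccc2)cs1` gives 20900 nM

Compound 2 stands at 20900 nM and lies within the scatter of compound 1, so the two cannot be ranked. The next compound is compound 3 `C=CC(=O)N(Cc1cccnc1)c1nc(-c2ccccc2)cs1`, and the change is pyridin-3-yl in place of tert-butoxycarbonyl on a saturated chain carbon bound to an amide-type nitrogen. In words, this is pyridin-3-yl in place of tert-butoxycarbonyl on a saturated chain carbon bound to an amide-type nitrogen, which also reads (tert-butoxycarbonyl)methyl to (pyridin-3-yl)methyl.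

Going by the values given here, only one measured step bears on this: a 1.1-fold higher number from compound 1 to compound 2 (0.05 log units; within the scatter), for (tert-butoxycarbonyl)methyl in place of hydrogen on an amide-type nitrogen. Among the compounds with values here, that step stays within the scatter, but no measured compound carries pyridin-3-yl, and a single step is thin support. On these data alone, no step beyond the scatter is therefore expected in this assay, and the direction remains open. The expected change is a 1.2-fold lower number from compound 2 to compound 3 (0.09 log units; within the scatter). For compound 3 the estimated value is 17000 nM, with an expected range from 6000 nM to 40000 nM.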

Compound 3, half-maximal inhibitory concentration: > 30000 nM
Compound 3 gave a limit, no number; the forecaster's own chance of this, stated with the estimate: 10%; at least 1.7-fold (0.24 log units) between middle value and limit.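

In this assay compound 3 carries a limit and not a number: the limit of > 30000 nM in this assay, at which 1 of the 3 values shown sits.

Against the tert-butoxycarbonyl compound the change reads as an at least 1.4-fold higher number from compound 2 to compound 3 (0.15 log units; that floor lies within the scatter), and against the compound with the amide hydrogen it reads as an at least 1.6-fold higher number from compound 1 to compound 3 (0.20 log units; that floor lies within the scatter). Both floors lie within the scatter, so compound 3 cannot yet be set apart from either neighbour. What is new is that an aromatic ring at this place, pyridin-3-yl on a saturated chain carbon bound to an amide-type nitrogen, gives no sign of a lower number, something the two earlier compounds could not show.

On these data alone, the true size of both steps stays open while compound 3 rests at a limit, so these three compounds do not settle whether pyridin-3-yl costs anything here or merely fails to help. Also open, as far as these compounds go, is whether a carboxylic acid in place of tert-butoxycarbonyl, or a phenyl or an aminoalkyl chain in place of pyridin-3-yl, on the same chain carbon would move the number in this assay in either direction.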